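The source may hold more compounds than are shown below. What is called first, only, known or untested is meant among the compounds shown, and "the series" means these compounds.

Measured compounds:
compound 1, `Nc1ccccc1NC(=O)CCCNCC(=O)Nc1cccc(Cl)c1`: > 100000 nM
compound 2, `Nc1ccccc1NC(=O)c1ccc(NCC(=O)Nc2ccc([N+](=O)[O-])cc2)cc1`: > 100000 nM

In a functional assay on HCT-116 cells (Homo sapiens) for inhibition, read by MTT assay, with a stated time of 2 days (a higher number here means that more compound is tolerated, a lower number that less compound is tolerated), compound 1 gives > 100000 nM, which is a limit of the assay rather than a number. Compound 2 gives > 100000 nM in this assay, again a limit and not a number. Compound 2 therefore stands at the limit of > 100000 nM in this assay, at which 2 of the 2 values shown sit, and nothing measured in the series falls below that limit, so no real spread of values is in hand. Compound 3, `Nc1ccccc1NC(=O)c1ccc(NCC(=O)Nc2cccc([N+](=O)[O-])c2)cc1`, is the next compound for this assay. It differs from compound 2 by 3-nitrophenyl in place of 4-nitrophenyl on an amide-type nitrogen. For the measured compounds named here, with both measured compounds sitting at the limit and no measured step to lean on, a change of this kind gives no ground to expect movement beyond the scatter in this assay. The expected step is a number no higher from compound 2 to compound 3 (the limit leaves the size open), essentially none. Compound 3 is therefore expected at 100000 nM, within 50000 nM to 200000 nM, and most likely reported once more only as a limit.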

Compound 3, concentration lethal to 50% of the cells: > 100000 nM
Compound 3: a limit, no number (the forecaster's own chance of this, stated with the estimate: 80%); the middle value lies on the limit itself.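

Compound 2 and compound 3 both stand only as limits in this assay; no step can be read for 3-nitrophenyl in place of 4-nitrophenyl. Still open, on these data alone, is where compound 1, compound 2 and compound 3 lie beyond that limit, and whether the two nitrophenyl groups differ at all.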